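A few compounds are considered here, and "the series" means these few. Any claim that something is new, unique, unknown or untested is made for them only; others in the source may bear on it.

Measured compounds in an assay on isolated protein for inhibition of aldehyde dehydrogenase 1A1 (Homo sapiens), read by spectrophotometry, tested at 10 uM; a lower number here means less inhibition, a higher number more inhibition at the concentration tested (going by the name of the read-out):
compound 1 `Cc1cccc(Cn2c(CN3CCN(C(=O)c4ccc(C(F)(F)F)cc4)CC3)nc3ccccc32)c1` gives 22.9%
compound 2 `O=C(C1CC1)N1CCN(Cc2nc3ccccc3n2Cc2ccccc2)CC1` gives 23.9%
compound 3 `Cc1cccc(Cn2c(CN3CCN(C(=O)c4ccc(F)cc4)CC3)nc3ccccc32)c1` gives 27.1%

Compound 2 stands second of the three numbers; its nearest neighbour is compound 1, a number within the scatter of it, and the furthest is compound 3, also within the scatter, so the three measured numbers cannot be ordered. Among the compounds with values here, the only step between compounds that differ in one place is a number 4.2 percentage points higher from compound 1 to compound 3 (within the scatter), and it lies on the amide side of the shared core, not on the benzyl ring, so it does not speak to the change examined here.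

Compound 4 `O=C(C1CC1)N1CCN(Cc2nc3ccccc3n2Cc2cccc(Cl)c2)CC1` is the next compound. It differs from compound 2 by chloro in place of hydrogen on an aromatic carbon. Within the data shown here, no measured pair shows what a substituent on the benzyl ring does in this assay; the one step available concerns a different ring and is itself within the scatter. The expectation is therefore no step beyond the scatter, that is, a number near that of compound 2. Compound 4 is estimated at 26%, with a range from 12% to 40%. The expected step is a number 2.1 percentage points higher from compound 2 to compound 4 (within the scatter).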

Compound 4, a percentage reported as inhibition, at one concentration (the size of the read-out at that concentration, not a potency): 71.6%
Compound 4: middle estimate off by 45.6 percentage points, on the low side, and the stated range ends below it.
By their numbers in this assay, from the lowest: compounds 1, 2 and 3 (each within the scatter of the next); then compound 4.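

In this assay, within the data shown here, the change from benzyl to 3-chlorobenzyl gives a number 47.7 percentage points higher from compound 2 to compound 4 (beyond the scatter) and so marks this ring as a place where the read-out responds strongly, whereas the only earlier step, a number 4.2 percentage points higher from compound 1 to compound 3 (within the scatter) and on the amide side, showed no such response. One heavy atom, a chlorine on an aromatic carbon meta to a large group, is enough for this step, with the amide and the shared core unchanged from compound 2. Nothing available accounts for the size of the step.

On these data alone, it remains open whether the step belongs to chloro specifically or to substitution at this place more generally; a fluoro, methoxy, trifluoromethyl, amine or carboxylic acid group here would separate those two readings. Also open, as far as these compounds go, are whether chloro elsewhere on this ring gives a similar step, whether the step carries over to other amides such as those of compound 1 and compound 3, and what potency lies behind a read-out taken at one concentration.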